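Replacing a sulfonamide with a sulfone in a kinase-cell series

A few compounds are considered here, and "the series" means these few. Any claim that something is new, unique, unknown or untested is made for them only; others in the source may bear on it.

Compound 2 `Cn1c(=O)c(S(=O)(=O)Nc2ccc(F)cc2F)cc2cnc(Nc3ccc4[nH]ccc4c3)nc21` is measured in a functional assay on K562 cells (Homo sapiens) for inhibition, read by trypan blue exclusion, with a stated time of 72 h (on this read-out higher numbers stand for weaker inhibition and lower numbers for stronger inhibition), at 5000 nM. Among the three measured compounds it stands together with compound 3 `Cn1c(=O)c(S(=O)(=O)c2ccc(F)cc2F)cc2cnc(Nc3ccc4cccc(O)c4n3)nc21` at the highest number; compound 3 gives 5000 nM, and there is no change between them at the digits shown. Going by the values given here, compound 1 `Cn1ccc2cc(Nc3ncc4cc(S(=O)(=O)c5ccc(F)cc5F)c(=O)n(C)c4n3)ccc21` gives 750 nM, and the step of a 6.7-fold higher number from compound 1 to compound 3 (0.82 log units; beyond the scatter) is the only one-place comparison available. Compound 4 `Cn1c(=O)c(S(=O)(=O)c2ccc(F)cc2)cc2cnc(Nc3ccc4[nH]ccc4c3)nc21` differs from compound 2 by 4-fluorophenyl in place of (2,4-difluorophenyl)amino on a sulfonyl sulfur. Among the compounds with values here, no measured step touches the group on the sulfonyl sulfur, so the expectation rests on compound 1, which also carries a sulfone and gives 750 nM. Compound 4 is therefore expected to show a step of a 4.2-fold lower number from compound 2 to compound 4 (0.62 log units; beyond the scatter), landing at an estimated 1200 nM, within a range of 300 nM to 5000 nM.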

Compound 4, half-maximal inhibitory concentration: 200 nM
Estimate against measurement, compound 4: 6.0-fold (0.78 log units) above; measured number below the stated range.
By their numbers in this assay, from the lowest: compound 4; then compound 1; then compounds 2 and 3 (each within the scatter of the next).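

Going by these compounds alone, on the sulfonyl sulfur, 4-fluorophenyl in place of (2,4-difluorophenyl)amino gives a 25-fold lower number from compound 2 to compound 4 (1.40 log units; beyond the scatter) in this assay, the first measured change at this position. The group on the sulfonyl sulfur therefore has a large influence on this read-out, and the entering group lacks the hydrogen-bond donor of the group it replaces. Nothing available explains the change. 

As far as these compounds go, this single step removes the amino nitrogen and one fluorine together, so their separate contributions remain unknown. From the compounds shown here alone, it also remains open how an unsubstituted phenyl or a morpholine on the sulfonyl sulfur would compare.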